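The compounds below may be only part of what the source reports. "The series", "measured", "known", "first", "only" and "open" are said of these compounds alone.

Notes on the series. Two members have numbers in an assay on cells for displacement of a labelled ligand from metabotropic glutamate receptor 2 (Homo sapiens), read by scintillation counting, with a stated time of 60 min; a lower number here means a stronger inhibitor, a higher number a weaker inhibitor. Compound 1 `Cc1cc(Oc2ccc(-c3ccn4c(CC5CC5)nnc4c3C(F)(F)F)cc2F)ccn1` gives 7.08 nM in this assay, the lowest of the two; compound 2 `CCOCc1nnc2c(C(F)(F)F)c(-c3ccc(Oc4ccc(C)nc4C)c(F)c3)ccn12` gives 11.8 nM in this assay. The two values lie within the scatter of one another, so nothing separates them in rank. Within the data shown here, no single-change step links these two compounds, and only their two values can be read side by side.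

Compound 3 `CC(C)Nc1ccc(-c2ccn3c(CC4CC4)nnc3c2C(F)(F)F)cc1F` is unmeasured. Compared with compound 1 the change is isopropylamino in place of (2-methylpyridin-4-yl)oxy on an aromatic carbon. A whole six-membered aromatic ring with its oxygen is taken away and a much smaller acyclic amine, carrying a hydrogen-bond donor, is put in its place. Among the measured compounds shown here, no measured pair in this set speaks to a change of this kind, so the size of the step rests on judgement alone. A step of an 8.5-fold higher number from compound 1 to compound 3 (0.93 log units; beyond the scatter) is expected in this assay, toward weaker binding and beyond the scatter. Compound 3 is estimated at 60 nM in this assay, with a range of 15 nM to 300 nM.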

Compound 3, inhibition constant: 8.91 nM
For compound 3 the middle estimate is 6.7-fold (0.83 log units) above the measured one, outside the stated range (below it).
By their numbers in this assay, from the lowest: compounds 1, 3 and 2 (each within the scatter of the next).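

In this assay, isopropylamino in place of (2-methylpyridin-4-yl)oxy gives a 1.3-fold higher number from compound 1 to compound 3 (0.10 log units; within the scatter), so this aromatic carbon, ortho to a fluoro group and para to a large group, can lose the six-membered aromatic ring and its oxygen with no change beyond the scatter. Among these compounds, this is the first reading at this position: a group of 4 heavy atoms with no ring and 1 hydrogen-bond donor reads alike with a group of 8 heavy atoms with a ring and 0 donors, so neither the ring nor the larger size is needed here to keep the number in this range. No measurement in hand says why the two groups read alike.

Open, from the compounds shown here alone, is whether the amine hydrogen of isopropylamino counts for anything, which isopropoxy or methyl(isopropyl)amino on the same carbon would test. Also open, going by these compounds, is how far this latitude extends, from a plain amino group at the small end to a longer chain such as hexylamino or a carboxylic acid on the same carbon.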